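A few compounds are considered here, and "the series" means these few. Any claim that something is new, unique, unknown or untested is made for them only; others in the source may bear on it.

Two compounds have readings so far in an ADME assay on microsomes from liver (Homo sapiens) for metabolic stability; a higher number here means faster removal of the compound, a lower number slower removal. Compound 1 (`CC(=O)N[C@@H]1CCC[C@H](C(=O)Nc2cc(-c3cnn4c3CCCC4)ccn2)C1`) gives < 3 mL.min-1.g-1, which is a limit of the assay and not a number. For the measured compounds named here, compound 2 (`CC(=O)N[C@@H]1CCC[C@H](C(=O)Nc2cc(-c3cnc4n3CCC4)c(Cl)cn2)C1`) gives 9.7 mL.min-1.g-1, the only actual number. Compound 3 (`CC(=O)N[C@@H]1CCC[C@H](C(=O)Nc2cc(-c3cnn4c3OCCC4)c(Cl)cn2)C1`) departs from compound 2 on an aromatic carbon, ortho to a chloro group: a group of 9 heavy atoms (6 carbon, 2 nitrogen, 1 oxygen; one five-membered aromatic ring with 2 hetero atoms, one six-membered non-aromatic ring with 2 hetero atoms) in place of a group of 8 heavy atoms (6 carbon, 2 nitrogen; one five-membered non-aromatic ring with 1 hetero atom, one five-membered aromatic ring with 2 hetero atoms), on an aromatic carbon. Going by the values given here, no measured step covers this change, so nothing beyond the scatter is expected in this assay. The expected change is a 1.6-fold lower number from compound 2 to compound 3 (0.21 log units; within the scatter), a small move towards slower removal at most. For compound 3 the estimated value is 6 mL.min-1.g-1, with a range of 3 mL.min-1.g-1 to 14 mL.min-1.g-1.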

Compound 3, intrinsic clearance in microsomes: < 3 mL.min-1.g-1
Compound 3 was reported as a limit; the forecaster's own chance of this, stated with the estimate: 20%; middle value at least 2.0-fold (0.30 log units) from the limit.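

In this assay, the aromatic carbon ortho to a chloro group now shows a change that can be read: an at least 3.2-fold lower number from compound 2 to compound 3 (0.50 log units; beyond the scatter). The group holding a six-membered non-aromatic ring with 2 hetero atoms thus moves the number beyond the scatter at this position. Compound 3 sits at a limit, so only a minimum size can be given for the step because the read-out ends there: the limit of < 3 mL.min-1.g-1 in this assay, at which 2 of the 3 values shown sit.

On these data alone, whether the ring oxygen or the ring size carries the step stays open, as the change alters both at once. As far as these compounds go, how a methoxy group or a plain phenyl ring would read on this carbon also remains open.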